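Replacing the carbamoyl of compound 2 with propyl

This account rests on a few compounds, and the source may have more. Where it says the series, first, only, none or still open, it means among the compounds named here.

Compound 2 `NC(=O)Cn1c(=O)n(C2OC(CO)[C@@H](O)[C@H]2O)c2nc(N)nc(O)c21` stands lowest of the two values measured in a functional assay on the whole organism (B cells) with Mus musculus as the target (a lower number here means a smaller maximal response, a higher number a larger maximal response), giving 32%, while compound 1 `Nc1nc(O)c2c(n1)n(C1OC(CO)[C@@H](O)[C@H]1O)c(=O)n2Cc1ccc(Cl)c(Cl)c1` gives 55%. Going by the values given here, the one measured step, a number 23 percentage points lower from compound 1 to compound 2 (beyond the scatter), changed the same position and lowered the response. Compound 3 `CCCCn1c(=O)n(C2OC(CO)[C@@H](O)[C@H]2O)c2nc(N)nc(O)c21` carries propyl in place of carbamoyl on a saturated chain carbon bound to an aromatic nitrogen. Among the compounds with values here, no measured step exchanges carbamoyl for propyl, so that step is only a loose guide. A small step is expected for compound 3, estimated as 40%, within 22% and 60%. The expected step from compound 2 is a number 8 percentage points higher from compound 2 to compound 3 (within the scatter), likely not beyond the scatter.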

Compound 3, largest response reached (reported as maximal response), in percent of the reference or control that the assay uses: 86%
Compound 3: the middle estimate sits 46 percentage points below what was measured, and the stated range ends below it.
By their numbers in this assay, from the lowest: compound 2; then compound 1; then compound 3.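

In this assay the exchange of carbamoyl for propyl gives a number 54 percentage points higher from compound 2 to compound 3 (beyond the scatter), and the exchange of 3,4-dichlorophenyl for propyl gives a number 31 percentage points higher from compound 1 to compound 3 (beyond the scatter). At this position, then, compound 3 has the largest response of the three, which shows that a high maximal response does not need the aromatic ring of compound 1. Nothing measured here explains this rise. As far as these compounds go, whether a longer chain such as hexyl, or an amine at the end of the propyl chain, would keep or raise this response remains open.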